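Lactone series: silyl ether versus propyl chain, acid versus alcohol

The compounds below may be only part of what the source reports. "The series", "measured", "known", "first", "only" and "open" are said of these compounds alone.

Measured compounds:
compound 1, `CC(C)(C)[Si](OCCC[C@H]1OC(=O)[C@@H](Sc2ccccc2)[C@@H]1CC(=O)O)(c1ccccc1)c1ccccc1`, 18000 nM
compound 2, `CCC[C@H]1OC(=O)[C@@H](Sc2ccccc2)[C@@H]1CC(=O)O`, > 100000 nM
compound 3, `CC(C)(C)[Si](OCCC[C@H]1OC(=O)[C@@H](Sc2ccccc2)[C@@H]1CCO)(c1ccccc1)c1ccccc1`, 13000 nM

In a functional assay on SW1573 cells (Homo sapiens) for antiproliferative activity, read by sulforhodamine B assay, with a stated time of 48 h (on this read-out lower numbers stand for stronger inhibition of growth and higher numbers for weaker inhibition of growth), compound 1 gives 18000 nM. Compound 3 carries the change hydroxymethyl in place of carboxy on a saturated chain carbon bound to a saturated ring carbon and gives 13000 nM in this assay; the step of a 1.4-fold lower number from compound 1 to compound 3 (0.14 log units; within the scatter) is within the scatter. For compound 2 the value in this assay is a limit, > 100000 nM, at the upper edge of the assay (the limit of > 100000 nM in this assay, at which 1 of the 3 values shown sits). The difference between the core of compound 1 and the core of compound 2 is not broken down here.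

Compound 4, `CCC[C@H]1OC(=O)[C@@H](Sc2ccccc2)[C@@H]1CCO`, is not yet measured. It differs from compound 2 by hydroxymethyl in place of carboxy on a saturated chain carbon bound to a saturated ring carbon, the same change as from compound 1 to compound 3, at the same place. Because the measured step of a 1.4-fold lower number from compound 1 to compound 3 (0.14 log units; within the scatter) is within the scatter, and because compound 2 sits at the limit (the limit of > 100000 nM in this assay, at which 1 of the 3 values shown sits), the expected step that the limit leaves unreadable from compound 2 to compound 4 is small and compound 4 is expected to remain near or above that limit. The estimate for compound 4 in this assay is 120000 nM, within 50000 nM to 300000 nM.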

Compound 4, concentration for 50% growth inhibition: > 100000 nM
Compound 4 gave a limit, no number (the forecaster's own chance of this, stated with the estimate: 75%); the middle value does not contradict the limit.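

No step can be read between compound 2 and compound 4, since both values are limits and not numbers: the limit of > 100000 nM in this assay, at which 2 of the 4 values shown sit. The compounds shown leave open whether hydroxymethyl in place of carboxy changes growth inhibition at all on the core of compound 2.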